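Thiazolyl amide in place of propylphenyl: notes on compound 4

The source may report more compounds than this note shows. Statements on the series, on what has been measured and on what is new or still open speak of the compounds shown alone.

Measured so far:
compound 1 `Cc1ccc(NC(=O)C2CCN(C/C=C/c3ccccc3)CC2)cc1` gives 33900 nM
compound 2 `CCCc1ccc(NC(=O)C2CCN(C/C=C/c3ccccc3)CC2)cc1` gives 9410 nM
compound 3 `O=C(Nc1ccccn1)C1CCN(C/C=C/c2ccccc2)CC1` gives 51100 nM

All three numbers come from a functional assay on HepG2 cells (Homo sapiens) for inhibition, read by MTT assay, with a stated time of 72 h; a higher number here means a weaker inhibitor, a lower number a stronger inhibitor. Compound 2 stands lowest of the three; its nearest neighbour is compound 1, and the step of a 3.6-fold lower number from compound 1 to compound 2 (0.56 log units; beyond the scatter) is already beyond the scatter. Compound 3 stands furthest from it, with a 5.4-fold higher number from compound 2 to compound 3 (0.73 log units; beyond the scatter). The swap of the aryl group on the amide-type nitrogen between compound 1 and compound 3 is a different matter: a 1.5-fold higher number from compound 1 to compound 3 (0.18 log units; within the scatter) is within the scatter.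

Compound 4 `O=C(Nc1nccs1)C1CCN(C/C=C/c2ccccc2)CC1` has not yet been measured. It differs from compound 2 in one place: 1,3-thiazol-2-yl in place of 4-propylphenyl on an amide-type nitrogen. Within the data shown here, the step that bears on this most directly is the one from compound 2 to compound 3, where the same 4-propylphenyl gave way to pyridin-2-yl, a five-to-six-membered heteroaryl of comparable size, and the number rose by a 5.4-fold higher number from compound 2 to compound 3 (0.73 log units; beyond the scatter). The step from compound 1 to compound 3 adds that a small heteroaryl and a small aryl on this nitrogen sit close together. For compound 4 a rise of similar size is therefore expected, roughly a 4.8-fold higher number from compound 2 to compound 4 (0.68 log units; beyond the scatter). Compound 4 is estimated at 45000 nM, with a range from 15000 nM to 130000 nM.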

Compound 4, half-maximal inhibitory concentration: 22400 nM
For compound 4 the middle estimate is 2.0-fold (0.30 log units) above the measured one, within the range that was stated.
By their numbers in this assay, from the lowest: compound 2; then compounds 4, 1 and 3 (each within the scatter of the next, the first and the last beyond it).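

In (this assay) the two heteroaryl groups on the amide-type nitrogen can now be told apart: 1,3-thiazol-2-yl in place of pyridin-2-yl gives (a 2.3-fold lower number from compound 3 to compound 4 (0.36 log units; beyond the scatter)). Yet 4-methylphenyl cannot be told apart from either of them, since 1,3-thiazol-2-yl in its place gives (a 1.5-fold lower number from compound 1 to compound 4 (0.18 log units; within the scatter)), and pyridin-2-yl in its place gives (a 1.5-fold higher number from compound 1 to compound 3 (0.18 log units; within the scatter)), so the small groups at this position span a narrow band whose two ends separate only just beyond the scatter. The 4-propylphenyl group keeps its lead over the five-membered ring as well (a 2.4-fold higher number from compound 2 to compound 4 (0.38 log units; beyond the scatter)), which makes compound 2 the only one of the four set apart from all the others.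

No measurement at hand accounts for the gap between the two heteroaryl groups or for the lead of 4-propylphenyl. Open, from the compounds shown here alone, is whether a propyl chain carried on the 1,3-thiazol-2-yl ring would bring the same gain as the chain extension on the phenyl ring (a 3.6-fold lower number from compound 1 to compound 2 (0.56 log units; beyond the scatter)), and how an amine or a carboxylic acid at this position would read.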